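The compounds below may be only part of what the source reports. "The series", "measured", "known", "first", "only" and "open" are said of these compounds alone.

Measured compounds in a functional assay on A-375 cells (Homo sapiens) for antiproliferative activity, read by trypan blue exclusion, with a stated time of 48 h, tested at 5 uM; on this read-out lower numbers stand for a stronger effect and higher numbers for a weaker effect at the one concentration tested:
- compound 1 `CC(=O)Nc1nc(-c2cccc(NS(=O)(=O)c3ccc(Br)cc3)c2)cs1`: 19.7%
- compound 2 `CCCCCCCCC#Cc1ccc(S(=O)(=O)Nc2cccc(-c3csc(NC(C)=O)n3)c2)cc1`: 8.9%

For the measured compounds named here, of the two numbers known so far, compound 1 stands highest. Going by the values given here, its nearest neighbour is compound 2, and the single measured step runs a number 10.8 percentage points lower from compound 1 to compound 2 (beyond the scatter), a modest change that nonetheless lies beyond the scatter, brought about by dec-1-yn-1-yl in place of bromo on an aromatic carbon.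

Compound 3 `CCCCCCCCc1ccc(S(=O)(=O)Nc2cccc(-c3csc(NC(C)=O)n3)c2)cc1` is the next member of the set, not yet measured in this assay. It differs from compound 1 as follows: octyl in place of bromo on an aromatic carbon. Among the compounds with values here, the one measured step that bears on this change is the one from compound 1 to compound 2, where an eight-carbon-bearing chain-type group likewise replaced bromo at the same place and the number fell modestly. On that basis, and only on that basis, a step of about the same size and in the same direction is expected here, that is a number 9.7 percentage points lower from compound 1 to compound 3 (within the scatter).

Compound 3 is therefore estimated at 10%, within a range from 3% to 19%.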

Compound 3, a percentage reported as activity, at one concentration (the size of the read-out at that concentration, not a potency): < 1%
Compound 3: no number, only a limit (the forecaster's own chance of this, stated with the estimate: 2%); at least 9 percentage points between middle value and limit.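

In this assay compound 3 gives < 1%, and this is a limit of the assay rather than a number: the limit of < 1% in this assay, at which 1 of the 3 values shown sits. Even so, the change of bromo to octyl on this aromatic carbon, para to a large group, can be read as a number at least 18.7 percentage points lower from compound 1 to compound 3 (beyond the scatter), so a second long carbon chain at this place goes with a stronger effect than bromo, and that effect no longer rests on dec-1-yn-1-yl alone. Set against dec-1-yn-1-yl, octyl gives a number at least 7.9 percentage points lower from compound 2 to compound 3 (that floor lies within the scatter), so the compounds shown do not firmly separate these two chains from each other.

As far as these compounds go, with only octyl and dec-1-yn-1-yl standing in for bromo at this place, it remains open how the effect follows chain length, whether a shorter chain such as butyl, a longer chain such as dodecyl, or a chain ending in an amine or a carboxylic acid would keep it. From the compounds shown here alone, it is also open how compound 3 and compound 2 would compare at a lower concentration, where neither read-out might sit so close to the limit.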